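A few compounds are considered here, and "the series" means these few. Any claim that something is new, unique, unknown or untested is made for them only; others in the source may bear on it.

Values in an ADME assay on HaCaT cells (Homo sapiens) for antiproliferative activity, with a stated time of 48 h (on this read-out lower numbers stand for stronger inhibition and higher numbers for weaker inhibition), for the series:
- compound 1 `CCN(CC)c1ccc(-c2ccc(C#N)cc2)nn1` gives > 25000 nM as a limit of the assay, not a number
- compound 2 `CCN(CC)c1ccc(-c2ccc(C(C)=O)cc2)nn1` gives 20000 nM
- compound 3 `CCN(CC)c1ccc(-c2ccc(C(=O)OC)cc2)nn1` gives 80 nM

Compound 3 holds the lowest number of the three, with compound 2 as its nearest measured neighbour. Compound 4 `CCN(CC)c1ccc(-c2ccc(C(=O)O)cc2)nn1` differs from it by hydrogen in place of methyl on an oxygen next to a carbonyl group in plain terms hydrogen in place of methyl on an oxygen next to a carbonyl group, or methoxycarbonyl to carboxy. Among the measured compounds shown here, no measured step makes this exact change. The closest evidence is a 250-fold lower number from compound 2 to compound 3 (2.40 log units; beyond the scatter) and an at least 310-fold lower number from compound 1 to compound 3 (2.49 log units; beyond the scatter) both large, whereas an at least 1.2-fold lower number from compound 1 to compound 2 (0.09 log units; that floor lies within the scatter) stays within the scatter. Compound 3 alone carries the methoxycarbonyl and alone reaches 80 nM so removing the methyl is expected to raise the number substantially, by an uncertain amount. The expected step is a 75-fold higher number from compound 3 to compound 4 (1.88 log units; beyond the scatter) toward weaker inhibition. For compound 4 the estimate is 6000 nM with an expected range of 400 nM to 25000 nM in this read-out.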

Compound 4, half-maximal inhibitory concentration: > 25000 nM
Compound 4: no number, only a limit; the forecaster's own chance of this, stated with the estimate: 30%; at least 4.1-fold (0.61 log units) between middle value and limit.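

Removing the single methyl on an oxygen next to a carbonyl group is enough to lose the low number of compound 3, giving an at least 310-fold higher number from compound 3 to compound 4 (2.49 log units; beyond the scatter). Among the compounds shown here, the remaining comparison, an at least 1.2-fold higher number from compound 2 to compound 4 (0.09 log units; that floor lies within the scatter), reaches only a floor within the scatter, so it gives no order for that pair. Compound 4 is recorded only as a limit of the assay: the limit of > 25000 nM in this assay, at which 2 of the 4 values shown sit.

The step between the two limit compounds, nitrile and carboxy, cannot be read. As far as these compounds go, whether an ethyl ester or an amide at this carbonyl would keep the low number of compound 3 remains open.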